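A Ring Nitrogen Swap on the Aryl Group

A few compounds are considered here, and "the series" means these few. Any claim that something is new, unique, unknown or untested is made for them only; others in the source may bear on it.

Three compounds were examined in an assay on isolated protein for agonist activity at Bile acid receptor (Homo sapiens), with a stated time of 30 min; a higher number here means that more compound is needed for the effect, a lower number that less compound is needed. For compound 1, `O=C(O)c1cc(F)c2nc(N3CCC4(CC3)OCC(c3c(-c5c(Cl)cccc5Cl)noc3C3CC3)O4)sc2c1`, the outcome is "not determined" (no result reported). Compound 3, `O=C(O)c1cc(F)c2nc(N3CC4C(/C=C/c5c(-c6c(Cl)cccc6Cl)noc5C5CC5)C4C3)sc2c1`, gives 609 nM. Compound 2, `O=C(O)c1ccc2cc(N3CCC4(C=C(c5c(-c6c(Cl)cc(F)cc6Cl)noc5C5CC5)C4)CC3)ccc2n1`, gives 2620 nM, the highest of the two reported numbers; the gap between compound 3 and compound 2 lies beyond the usual scatter, and compound 1 contributes no number. Compound 4, `O=C(O)c1ccc2cc(N3CCC4(C=C(c5c(-c6c(Cl)cncc6Cl)noc5C5CC5)C4)CC3)ccc2n1`, has not yet been measured. It differs from compound 2 in one place: 3,5-dichloropyridin-4-yl in place of 2,6-dichloro-4-fluorophenyl on an aromatic carbon. Within the data shown here, no measured pair shows this same change, so the size of the step in this assay cannot be read from earlier values. The change is small in what it counts, and the expectation is for a step no larger than the scatter, in either direction. The step from compound 2 to compound 4 is expected to be a 1.0-fold lower number from compound 2 to compound 4 (0.02 log units; within the scatter). Compound 4 is accordingly estimated at 2500 nM, within a range from 900 nM to 7000 nM.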

Compound 4, half-maximal effective concentration: 921 nM
The estimate for compound 4 lay 2.7-fold (0.43 log units) above the measured number; the measured number falls inside the stated range.
By their numbers in this assay, from the lowest: compounds 3 and 4 (each within the scatter of the next); then compound 2.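

In this assay, the aryl group on an aromatic carbon of a five-membered aromatic ring with 1 nitrogen and 1 oxygen proved responsive to change: 3,5-dichloropyridin-4-yl in place of 2,6-dichloro-4-fluorophenyl gives a 2.8-fold lower number from compound 2 to compound 4 (0.45 log units; beyond the scatter). Among these compounds, the earlier compounds offered no pair differing in one place, and this is the first step that can be read at this position, with the size of the change beyond the scatter. Nothing in hand explains the step.

From the compounds shown here alone, it remains open whether the step follows the ring nitrogen that enters or the fluorine that leaves, and how a nitrile or a methoxy group on that aryl ring would read on this core. Going by these compounds, whether the same swap would hold on the cores of compound 1 and compound 3 is also open.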